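Vero cytotoxicity notes: from compound 1 toward compound 4

The source may report more compounds than this note shows. Statements on the series, on what has been measured and on what is new or still open speak of the compounds shown alone.

Compound 1 is `CCN(CC)c1cc2[nH]c(C3CCCCC3)nc2cc1NC(=O)NCc1ccccc1`. In an ADME assay on Vero cells (Chlorocebus sabaeus) for cytotoxicity, read by resazurin assay, with a stated time of 3 days (on this read-out lower numbers stand for stronger inhibition and higher numbers for weaker inhibition), compound 1 reaches only the limit of the assay, > 100 ug/mL, so no number is known for it. Compound 2, `O=C(NCc1ccccc1)Nc1cc2nc(C3CCCCC3)[nH]c2cc1N1CCCC1`, likewise stops at a limit in this assay, namely > 100 ug/mL. Compound 3, `CCCCOC(=O)Nc1cc2nc(C3CCCCC3)[nH]c2cc1N(CC)CCN(CC)CC`, also stops at a limit in this assay, here > 50 ug/mL. Within the data shown here, the one change recorded between measured compounds, pyrrolidin-1-yl in place of diethylamino on an aromatic carbon, gives a step that the two limits leave unreadable from compound 1 to compound 2, unreadable because both ends sit at the limit of > 100 ug/mL in this assay, at which 2 of the 3 values shown sit. Against this background, compound 4 is `CCN(CC)c1cc2[nH]c(C3CCCCC3)nc2cc1NC(=O)c1ccc(OC(F)F)cc1`, made from compound 1 by 4-(difluoromethoxy)phenyl in place of benzylamino on a carbonyl carbon. Among the measured compounds shown here, no measured step touches the carbonyl carbon, so none of the measured steps reads directly on this change. With every measured value resting at a limit, two at the limit of > 100 ug/mL in this assay, at which 2 of the 3 values shown sit, and one at the limit of > 50 ug/mL in this assay, at which 1 of the 3 values shown sits, the expectation is no step beyond the scatter, expressed as a number no higher from compound 1 to compound 4 (the limit leaves the size open). Compound 4 is therefore estimated at 100 ug/mL in this assay, with an expected range from 40 ug/mL to 250 ug/mL, and it is expected that the assay will most likely again report only a limit rather than a number.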

Compound 4, half-maximal inhibitory concentration: > 100 ug/mL
Compound 4 gave a limit, no number; the forecaster's own chance of this, stated with the estimate: 65%; the middle value sits exactly at the limit.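

No step can be read between compound 1 and compound 4: in this assay both stop at a limit, with no number for either. The compounds shown leave open where any of them would give a true half-maximal value, and whether 4-(difluoromethoxy)phenyl in place of benzylamino on a carbonyl carbon changes cytotoxicity at all.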